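Shifting the Methyl Around the Phenyl Ring

The source may hold more compounds than are shown below. What is called first, only, known or untested is meant among the compounds shown, and "the series" means these compounds.

Three compounds share one core and differ only in the group on a single aromatic carbon. Compound 1 `Clc1ccc(-c2cc(-c3ccsc3)nc(-c3ccco3)c2)o1` carries a furan-2-yl group there; in a functional assay on HeLa cells (Homo sapiens) for cytotoxicity, in the presence of a further agent that is not named here (on this read-out higher numbers stand for weaker inhibition and lower numbers for stronger inhibition), compound 1 gives only a limit, > 50000 nM, and not a number (the limit of > 50000 nM in this assay, at which 1 of the 3 values shown sits). Compound 2 `Clc1ccc(-c2cc(-c3ccsc3)nc(-c3ccccc3Cl)c2)o1`, with a 2-chlorophenyl group, gives 8070 nM in this assay. Compound 3 `Cc1cccc(-c2cc(-c3ccc(Cl)o3)cc(-c3ccsc3)n2)c1`, with a 3-methylphenyl group, gives 20300 nM in this assay; of the two numbers shown this is the highest, and the step of a 2.5-fold higher number from compound 2 to compound 3 (0.40 log units; beyond the scatter) is modest but beyond the scatter. The steps of an at least 6.1-fold lower number from compound 1 to compound 2 (0.79 log units; beyond the scatter) and an at least 2.4-fold lower number from compound 1 to compound 3 (0.39 log units; beyond the scatter) show that either phenyl group brings the number below the limit.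

Compound 4 `Cc1ccccc1-c1cc(-c2ccc(Cl)o2)cc(-c2ccsc2)n1` has not yet been measured. It differs from compound 3 by 2-methylphenyl in place of 3-methylphenyl on an aromatic carbon. Within the data shown here, no measured step swaps the two methylphenyl groups directly; the closest guide is compound 2, whose 2-chlorophenyl group gave the lowest number. A modest lowering is therefore expected, a 1.8-fold lower number from compound 3 to compound 4 (0.27 log units; within the scatter). Compound 4 is estimated at 11000 nM, with a range from 4000 nM to 30000 nM.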

Compound 4, half-maximal inhibitory concentration: 9770 nM
The estimate for compound 4 lay 1.1-fold (0.05 log units) above the measured number, within the range that was stated.
By their numbers in this assay, from the lowest: compounds 2 and 4 (each within the scatter of the next); then compound 3. At a limit, above all of these: compound 1.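

In this assay, a move of the methyl group alone gives a 2.1-fold lower number from compound 3 to compound 4 (0.32 log units; beyond the scatter), so at this position the place of the methyl on the phenyl ring counts, and not only the presence of a phenyl ring. Among these compounds, with methyl in place of chloro, the 2-methylphenyl and 2-chlorophenyl groups cannot be told apart (a 1.2-fold higher number from compound 2 to compound 4 (0.08 log units; within the scatter)), which the earlier compounds could not show. Compound 1 gives only a limit, and the 2-methylphenyl group also brings the number under it (an at least 5.1-fold lower number from compound 1 to compound 4 (0.70 log units; beyond the scatter)).

As far as these compounds go, whether a chloro group on the phenyl ring responds to being moved as the methyl does stays open. So does the effect of an amine or a carboxylic acid on the phenyl ring in place of the methyl, or of a phenyl ring with neither methyl nor chloro.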